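This account rests on a few compounds, and the source may have more. Where it says the series, first, only, none or still open, it means among the compounds named here.

In a functional assay on NALM-6 cells (Homo sapiens) for cytotoxicity, with a stated time of 72 h (a higher number here means that more compound is needed for the effect, a lower number that less compound is needed), compound 1 `C=C[C@@](C)(/C=C/c1ccc(O)c(CO)c1)CCC=C(C)C` gives 16400 nM and compound 3 `C=C[C@@](C)(/C=C/c1ccc(O)c(/C=C/C(=O)OCC)c1)CCC=C(C)C` gives 20900 nM, so compound 3 stands level with compound 1 within the scatter, as a 1.3-fold higher number from compound 1 to compound 3 (0.11 log units; within the scatter) shows. Compound 2 `C=C[C@@](C)(/C=C/c1ccc(O)c(/C=C/C#N)c1)CCC=C(C)C` is reported only as a limit of the assay, > 43400 nM. Against that limit, the data give an at least 2.0-fold lower number from compound 2 to compound 3 (0.31 log units; beyond the scatter). Compound 4 `C=C[C@@](C)(/C=C/c1ccc(O)c(/C=C(\C)C(=O)OCC)c1)CCC=C(C)C` carries one change from compound 3, (2-(ethoxycarbonyl)prop-1-en-1-yl in place of 2-(ethoxycarbonyl)ethenyl on an aromatic carbon), with 2-(ethoxycarbonyl)prop-1-en-1-yl in place of 2-(ethoxycarbonyl)ethenyl on an aromatic carbon. Among the compounds with values here, no measured step isolates this change. The closest guide is compound 3 itself, whose whole replacement of hydroxymethyl stayed within the scatter at a 1.3-fold higher number from compound 1 to compound 3 (0.11 log units; within the scatter). No step beyond the scatter is therefore expected, and the estimated step is a 1.0-fold lower number from compound 3 to compound 4 (0.02 log units; within the scatter). Compound 4 is expected at 20000 nM, with an estimated range from 9000 nM to 43000 nM.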

Compound 4, half-maximal effective concentration: > 7500 nM
Compound 4 was reported as a limit (the forecaster's own chance of this, stated with the estimate: 15%); the middle value is on the limit's open side.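

In this assay compound 4 is reported only as a limit, > 7500 nM, and its steps from compound 1, compound 2 and compound 3 cannot be read. As far as these compounds go, whether 2-(ethoxycarbonyl)prop-1-en-1-yl in place of 2-(ethoxycarbonyl)ethenyl changes the number at all remains open.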